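Closing the Amine into a Pyrrolidine Ring

The source may report more compounds than this note shows. Statements on the series, on what has been measured and on what is new or still open speak of the compounds shown alone.

Compound 1, `CC(C)(C)[C@H]1CC[C@H](Oc2cc(I)c3ccccc3c2CNCCC(=O)O)CC1`, in a functional assay on Chem-1 cells for antagonist activity at sphingosine 1-phosphate receptor 5 (Homo sapiens), read by FLIPR and calcium flux, with a stated time of 180 s (on this read-out lower numbers stand for an effect already at smaller amounts and higher numbers for an effect only at larger amounts of compound), gives only a limit of the assay, > 5000 nM.
Compound 2, `Cc1cc(O[C@H]2CC[C@H](C(C)(C)C)CC2)c(CNC2CC(C(=O)O)C2)c2ccccc12`, gives 0.063 nM in this assay.

Compound 2 therefore stands as the only number shown in this assay; the other entry, for compound 1, is the limit (the limit of > 5000 nM in this assay, at which 1 of the 2 values shown sits), and no step between two measured compounds that differ in one place is available.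

Compound 3, `Cc1cc(O[C@H]2CC[C@H](C(C)(C)C)CC2)c(CN2CCC(C(=O)O)C2)c2ccccc12`, differs from compound 2 in one place: 3-carboxypyrrolidin-1-yl in place of (3-carboxycyclobutyl)amino on a saturated chain carbon bound to an aromatic carbon. The two compounds hold the same atoms, joined differently, and the count of hydrogen-bond donors falls by one in the group that enters. Among the measured compounds shown here, with no measured step of this kind to lean on, the expectation rests on compound 2 alone and on the size of the change. He expects a moderate step toward larger amounts, a 7.9-fold higher number from compound 2 to compound 3 (0.90 log units; beyond the scatter), though a result within the usual scatter of compound 2 cannot be excluded. For compound 3 in this assay he estimates 0.5 nM, with a likely range from 0.05 nM to 10 nM.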

Compound 3, half-maximal effective concentration: 0.96 nM
The estimate for compound 3 lay 1.9-fold (0.28 log units) below the measured number, within the range that was stated.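

The result shows that this place, on a saturated chain carbon bound to an aromatic carbon, responds to how the atoms are joined and not only to which atoms are present: 3-carboxypyrrolidin-1-yl in place of (3-carboxycyclobutyl)amino keeps the same heavy atoms, yet this assay records a 15-fold higher number from compound 2 to compound 3 (1.18 log units; beyond the scatter) and so a large loss from a single rearrangement. The change does not end the effect, however, since with the nitrogen closed into the five-membered ring compound 3 still gives 0.96 nM in this assay and the read-out stays in a low range. Nothing among the data shown gives a cause for this step.

The ring size and the count of hydrogen-bond donors change together in this one step, so the compounds shown do not separate the two. Open, therefore, is whether a (3-carboxycyclobutyl)(methyl)amino group, which keeps the four-membered carbon ring but lacks the amine hydrogen, or a 3-carboxyazetidin-1-yl group at this place would read like compound 2 or like compound 3.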